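Amino for isopropyl: working notes on compound 3

A few compounds are considered here, and "the series" means these few. Any claim that something is new, unique, unknown or untested is made for them only; others in the source may bear on it.

Values in a functional assay on SGC-7901 cells (Homo sapiens) for antiproliferative activity, read by MTT assay, with a stated time of 48 h; a lower number here means a stronger inhibitor, a higher number a weaker inhibitor:
Compound 1 `CCOc1ccc(-c2nnc(SCc3ccc(Cl)nc3)o2)cc1`: 4.97 ug/mL
Compound 2 `CC(C)c1ccc(-c2nnc(SCc3ccc(Cl)nc3)o2)cc1`: 4.32 ug/mL
Compound 3 `Nc1ccc(-c2nnc(SCc3ccc(Cl)nc3)o2)cc1`: not yet measured

Compound 2 stands level with compound 1, the two numbers lying within the scatter of each other. The next change is amino in place of isopropyl on an aromatic carbon, para to a large group: amino in place of isopropyl on an aromatic carbon. Among the measured compounds shown here, only one measured step bears on it: a 1.2-fold lower number from compound 1 to compound 2 (0.06 log units; within the scatter), with isopropyl in place of ethoxy, and that step stays within the scatter. This single step is thin evidence, so no step beyond the scatter and no firm direction is expected in this assay. The expected step is a 1.1-fold higher number from compound 2 to compound 3 (0.05 log units; within the scatter). For compound 3 the estimate is 4.8 ug/mL, with an expected range of 2 ug/mL to 11 ug/mL.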

Compound 3, half-maximal inhibitory concentration: 8.48 ug/mL
Beside the measured number, compound 3's estimate is 1.8-fold (0.25 log units) below it; the measured number falls inside the stated range.
By their numbers in this assay, from the lowest: compounds 2, 1 and 3 (each within the scatter of the next).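

In this assay, amino in place of isopropyl gives a 2.0-fold higher number from compound 2 to compound 3 (0.29 log units; within the scatter) and amino in place of ethoxy gives a 1.7-fold higher number from compound 1 to compound 3 (0.23 log units; within the scatter) on this aromatic carbon, para to a large group. Among the compounds shown here, three different groups have now stood at this place, including one with a hydrogen-bond donor, and no step among compounds 1, 2 and 3 goes beyond the scatter. No measurement at hand explains these numbers.

Going by these compounds, it remains open whether a carboxylic acid or a longer chain at this place would give a step beyond the scatter.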